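Varying the group on the ring nitrogen of a benzimidazole-acid series

The source may hold more compounds than are shown below. What is called first, only, known or untested is meant among the compounds shown, and "the series" means these compounds.

Measured compounds in an assay on Huh-7 cells for agonist activity at Bile acid receptor (Homo sapiens), read by a luciferase reporter; a lower number here means that less compound is needed, a higher number that more compound is needed for the effect:
- compound 1 `CCC(CC)n1c(-c2ccc(OCc3c(-c4c(Cl)cccc4Cl)noc3C(C)C)cc2F)nc2ccc(C(=O)O)cc21` gives 1.3 nM
- compound 2 `CC(C)c1onc(-c2c(Cl)cccc2Cl)c1COc1ccc(-c2nc3ccc(C(=O)O)cc3n2CC(C)(C)C)cc1` gives 13 nM
- compound 3 `CCn1c(-c2ccc(OCc3c(-c4c(Cl)cccc4Cl)noc3C(C)C)cc2)nc2ccc(C(=O)O)cc21` gives 2.31 nM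

Compound 2 has the highest number of the three in this assay; compound 3 is nearest to it, and compound 1 is furthest.

Compound 4 `CC(C)c1onc(-c2c(Cl)cccc2Cl)c1COc1ccc(-c2nc3ccc(C(=O)O)cc3n2C2CCCCCC2)cc1` has not yet been measured. It differs from compound 2 in one place: cycloheptyl in place of neopentyl on an aromatic nitrogen. Among the measured compounds shown here, only one measured step bears on this position, a 5.6-fold lower number from compound 2 to compound 3 (0.75 log units; beyond the scatter), which shows that the group on the aromatic nitrogen can shift the number in this assay by a modest amount. For the measured compounds named here, compound 1, which carries a branched chain at the same position together with a further change elsewhere, also gives a lower number than compound 2, but no single step connects those two compounds. On this basis the cycloheptyl group in compound 4 is expected to give a lower number than compound 2, that is a 3.3-fold lower number from compound 2 to compound 4 (0.51 log units; beyond the scatter), with the estimate for compound 4 in this assay being 4 nM, between 1 nM and 15 nM.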

Compound 4, half-maximal effective concentration: 14.8 nM
Compound 4: the middle estimate sits 3.7-fold (0.57 log units) below what was measured; low and high end bracket the measured number.
By their numbers in this assay, from the lowest: compounds 1 and 3 (each within the scatter of the next); then compounds 2 and 4 (each within the scatter of the next).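

In this assay the exchange of neopentyl for cycloheptyl on the aromatic nitrogen gives a 1.1-fold higher number from compound 2 to compound 4 (0.06 log units; within the scatter) and so does not separate the open chain from the seven-membered ring. The earlier step showed only that this position can move the number, whereas ethyl against cycloheptyl now gives a 6.4-fold higher number from compound 3 to compound 4 (0.81 log units; beyond the scatter) and places the ethyl of compound 3 apart from both neopentyl and cycloheptyl. No measurement at hand accounts for this result.

On these data alone, whether a cyclopentyl or cyclopropyl ring, or a propyl chain, would stand with ethyl or with neopentyl and cycloheptyl remains open. Compound 1 differs from these compounds in more than one place, so what its branched chain contributes alone also stays unresolved.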